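The source may report more compounds than this note shows. Statements on the series, on what has been measured and on what is new or still open speak of the compounds shown alone.

Measured in a functional assay on DA-3 cells for cytotoxicity against DA-3 cell line (Mus musculus), read by MTT assay; on this read-out higher numbers stand for weaker inhibition and lower numbers for stronger inhibition:
- compound 1 `CC(=O)O[C@@H]1OC(=O)[C@](C)(C(C)=O)[C@@H]1C`: 7000 nM
- compound 2 `CC(=O)O[C@@H]1OC(=O)[C@](C)(C(=O)CBr)[C@@H]1C`: 4000 nM

For the measured compounds named here, compound 1 stands within the scatter of compound 2, the only other measured compound, so the pair sets no order. Compound 3 `CC(=O)O[C@@H]1OC(=O)[C@@H](C(C)=O)[C@@H]1C` has hydrogen in place of methyl on a saturated ring carbon. Going by the values given here, the only measured step, a 1.8-fold lower number from compound 1 to compound 2 (0.24 log units; within the scatter), is a change on a chain carbon, so it bears only indirectly and no measured step touches this ring carbon. The step expected in this assay is a 1.2-fold lower number from compound 1 to compound 3 (0.07 log units; within the scatter), so none beyond the scatter is anticipated. For compound 3 the estimate is 6000 nM, with an expected range of 2500 nM to 15000 nM.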

Compound 3, half-maximal inhibitory concentration: > 50000 nM
Compound 3: no number, only a limit; the forecaster's own chance of this, stated with the estimate: 10%; at least 8.3-fold (0.92 log units) between middle value and limit.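

In this assay hydrogen in place of methyl on this saturated ring carbon gives an at least 7.1-fold higher number from compound 1 to compound 3 (0.85 log units; beyond the scatter) and is the only step shown beyond the scatter, so at this position the methyl cannot be removed without a loss of cytotoxicity. Compound 3 gives only a limit of > 50000 nM and no number, so the full size of the step stays unknown: the limit of > 50000 nM in this assay, at which 1 of the 3 values shown sits.

On these data alone, whether an ethyl group or a longer chain on this ring carbon keeps the cytotoxicity of compound 1 remains open. Also open, as far as these compounds go, is whether bromo on the chain carbon would make any difference without this methyl.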